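Cytotoxicity Outlook for a Hydroxyphenyl Sulfanyl Analogue

The source may report more compounds than this note shows. Statements on the series, on what has been measured and on what is new or still open speak of the compounds shown alone.

Compound 2 `OB1OCc2ccc(-n3cc(Sc4ccc(Cl)c(Cl)c4)c4ccccc43)cc21` carries a (3,4-dichlorophenyl)sulfanyl group on the shared core. In an ADME assay on L929 cells (Mus musculus) for cytotoxicity, read by resazurin assay, with a stated time of 72 h (on this read-out lower numbers stand for stronger inhibition and higher numbers for weaker inhibition), compound 2 gives > 10 ug/mL, which is a limit of the assay and not a number. Compound 1 `OB1OCc2ccc(-n3ccc4ccccc43)cc21` lacks that group. In this assay compound 1 gives > 10 ug/mL, again a limit. Compound 3 `OB1OCc2ccc(-n3cc(Sc4ccc(Cl)cc4)c4ccccc43)cc21` bears a (4-chlorophenyl)sulfanyl group instead. In this assay compound 3 gives > 10 ug/mL, also a limit. Thus (the limit of > 10 ug/mL in this assay, at which 3 of the 3 values shown sit), and the steps a step that the two limits leave unreadable from compound 1 to compound 2, a step that the two limits leave unreadable from compound 1 to compound 3 and a step that the two limits leave unreadable from compound 2 to compound 3 cannot be read in size or direction. Compound 4 `OB1OCc2ccc(-n3cc(Sc4ccccc4O)c4ccccc43)cc21` differs from compound 2 by 2-hydroxyphenyl in place of 3,4-dichlorophenyl on a sulfur. Among the measured compounds shown here, no measured step bears on this particular change, and none of the measured steps yields a readable size. One therefore expects compound 4 to sit at a limit as well, with the expected step that the limit leaves unreadable from compound 2 to compound 4 amounting to none beyond the scatter in this assay. Compound 4 is estimated at 15 ug/mL, between 7 ug/mL and 40 ug/mL.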

Compound 4, half-maximal inhibitory concentration: > 10 ug/mL
Compound 4: no number, only a limit (the forecaster's own chance of this, stated with the estimate: 80%); the middle value lies beyond the limit too.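

Among the compounds shown here, compound 4 sits at a limit in this assay, as do compound 1, compound 2 and compound 3, so no step involving compound 4 can be read in size or direction: the limit of > 10 ug/mL in this assay, at which 4 of the 4 values shown sit. The compounds shown leave open whether any of these sulfanyl groups changes cytotoxicity at all.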